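The source may report more compounds than this note shows. Statements on the series, on what has been measured and on what is new or still open speak of the compounds shown alone.

Measured compounds:
Compound 1, `CCS(=O)(=O)Nc1cc(-c2ccc3ncnc(Nc4cccc(F)c4)c3c2)cnc1OC`, in a functional assay on MCF7 cells (Homo sapiens) for cytotoxicity, read by sulforhodamine B assay, with a stated time of 72 h (on this read-out lower numbers stand for stronger inhibition and higher numbers for weaker inhibition), gives 8020 nM.
Compound 2, `CCS(=O)(=O)Nc1cc(-c2ccc3ncnc(Nc4ccc(OC(F)(F)F)cc4)c3c2)cnc1OC`, gives 23700 nM.
Compound 3, `CCS(=O)(=O)Nc1cc(-c2ccc3ncnc(Nc4ccc(OC)c(Cl)c4)c3c2)cnc1OC`, gives 3320 nM.

Compound 3 has the lowest number of the three; the two steps into it are a 2.4-fold lower number from compound 1 to compound 3 (0.38 log units; beyond the scatter) and a 7.1-fold lower number from compound 2 to compound 3 (0.85 log units; beyond the scatter). Compound 4, `CCS(=O)(=O)Nc1cc(-c2ccc3ncnc(Nc4ccc(Cl)c(C(=O)OC)c4)c3c2)cnc1OC`, differs from compound 3 only in the group on the same nitrogen: 4-chloro-3-(methoxycarbonyl)phenyl in place of 3-chloro-4-methoxyphenyl on a nitrogen on an aromatic ring. Going by the values given here, no measured step swaps exactly these two groups; the two steps into compound 3 only show that changing the group on this nitrogen moves the number by a modest amount in either direction. Compound 4 is therefore expected to land a little higher than compound 3, a step of about a 2.0-fold higher number from compound 3 to compound 4 (0.29 log units; within the scatter), with wide uncertainty. The estimate for compound 4 in this assay is 6500 nM, within 2200 nM to 20000 nM.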

Compound 4, half-maximal inhibitory concentration: 1430 nM
The estimate for compound 4 lay 4.5-fold (0.66 log units) above the measured number; measured number below the stated range.
By their numbers in this assay, from the lowest: compound 4; then compound 3; then compound 1; then compound 2.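

In this assay, the new group shows that this nitrogen can carry a larger substituent with a methoxycarbonyl group and still give a lower number, with a 2.3-fold lower number from compound 3 to compound 4 (0.37 log units; beyond the scatter). The gaps to the other two compounds are wider, with a 5.6-fold lower number from compound 1 to compound 4 (0.75 log units; beyond the scatter) and a 17-fold lower number from compound 2 to compound 4 (1.22 log units; beyond the scatter), so compound 4 now has the lowest number of the four. No measurement shown here explains this gain.

Going by these compounds, it remains open whether the methoxycarbonyl group, the chlorine or their combination accounts for the step. On these data alone, how a carboxylic acid or an amide in place of that ester would read also remains open.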